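A few compounds are considered here, and "the series" means these few. Any claim that something is new, unique, unknown or untested is made for them only; others in the source may bear on it.

Series in a functional assay on MCF7 cells (Homo sapiens) for cytotoxicity, read by MTT assay, with a stated time of 72 h; on this read-out lower numbers stand for stronger inhibition and higher numbers for weaker inhibition:
Compound 1, `CCc1ccc(-c2ccnc(C(=O)Nc3ccc(Oc4ccnc5[nH]ccc45)c(F)c3)c2)cc1`, gives 7470 nM.
Compound 2, `COc1ccc(-c2ccnc(C(=O)Nc3ccc(Oc4ccnc5[nH]ccc45)c(F)c3)c2)cc1`, gives 9110 nM.
Compound 3, `O=C(Nc1ccc(Oc2ccnc3[nH]ccc23)c(F)c1)c1cc(-c2ccc(F)cc2)ccn1`, gives 9520 nM.

Compound 3 holds the highest of the three numbers, but its steps to both other compounds fall within the scatter: a 1.3-fold higher number from compound 1 to compound 3 (0.11 log units; within the scatter) and a 1.0-fold higher number from compound 2 to compound 3 (0.02 log units; within the scatter). Likewise a 1.2-fold higher number from compound 1 to compound 2 (0.09 log units; within the scatter). Across the three measured compounds, exchanging the group at this one place has not moved the read-out beyond the scatter.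

Compound 4, `O=C(Nc1ccc(Oc2ccnc3[nH]ccc23)c(F)c1)c1cc(-c2ccc(C(F)(F)F)cc2)ccn1`, differs from compound 3 in one place: trifluoromethyl in place of fluoro on an aromatic carbon. Going by the values given here, no measured step makes exactly this change; the nearest guide is the set of steps just described, each within the scatter, in which ethyl, methoxy and fluoro at the same place all give comparable numbers. Trifluoromethyl carries more heavy atoms than any of the three groups tried, which adds uncertainty, but nothing shown argues for a shift beyond the scatter in either direction. Compound 4 is therefore expected to sit close to compound 3, with a 1.0-fold lower number from compound 3 to compound 4 (0.00 log units; within the scatter). The estimate for compound 4 in this assay is 9500 nM, with a range of 3500 nM to 26000 nM.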

Compound 4, half-maximal inhibitory concentration: 8550 nM
Compound 4: middle estimate off by 1.1-fold (0.05 log units), on the high side; the range from low to high includes it.
By their numbers in this assay, from the lowest: compounds 1, 4, 2 and 3 (each within the scatter of the next).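

In this assay, trifluoromethyl on the aromatic carbon para to a large group gives no step beyond the scatter from any of the three earlier groups: fluoro (a 1.1-fold lower number from compound 3 to compound 4 (0.05 log units; within the scatter)), methoxy (a 1.1-fold lower number from compound 2 to compound 4 (0.03 log units; within the scatter)) and ethyl (a 1.1-fold higher number from compound 1 to compound 4 (0.06 log units; within the scatter)). The level read-out therefore extends to a group of 4 heavy atoms, where the entering group replaces fluoro with its 1 heavy atom, and none of the four compounds goes against this. No supporting data bear on why the read-out stays level at this place.

On these data alone, whether an amine, a carboxylic acid or a longer chain at this place would move the number beyond the scatter remains open. As far as these compounds go, all four compounds share the rest of the structure, so whether the same level read-out would hold on a changed core also remains open.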